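This account rests on a few compounds, and the source may have more. Where it says the series, first, only, none or still open, it means among the compounds named here.

Of the compounds shown here, three of a shared core have been tested in a functional assay on PC-3 cells (Homo sapiens) for cytotoxicity, read by sulforhodamine B assay, with a stated time of 48 h; a lower number here means a stronger inhibitor, a higher number a weaker inhibitor. Compound 1 `C[C@H]1CC[C@@H]2[C@@H](OC(=O)[C@]23CC(c2c(Cl)cccc2Cl)=NO3)[C@]2(C)C(=O)C=C[C@@]12O` carries a 2,6-dichlorophenyl on a carbon with a double bond to nitrogen and gives 56000 nM. Compound 2 `COc1ccc(C2=NO[C@]3(C2)C(=O)O[C@@H]2[C@H]3CC[C@H](C)[C@]3(O)C=CC(=O)[C@@]23C)cc1` carries a 4-methoxyphenyl at the same place and gives 35000 nM. Compound 3 `C[C@H]1CC[C@@H]2[C@@H](OC(=O)[C@]23CC(c2ccc(O)cc2)=NO3)[C@]2(C)C(=O)C=C[C@@]12O` carries a 4-hydroxyphenyl there and gives 20000 nM, the lowest of the three numbers; its separation from compound 2 is a 1.8-fold lower number from compound 2 to compound 3 (0.24 log units; within the scatter), while from compound 1 the step is a 2.8-fold lower number from compound 1 to compound 3 (0.45 log units; beyond the scatter). The step of a 1.6-fold lower number from compound 1 to compound 2 (0.20 log units; within the scatter) likewise stays within the scatter.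

Compound 4 `C[C@H]1CC[C@@H]2[C@@H](OC(=O)[C@]23CC(c2ccccc2F)=NO3)[C@]2(C)C(=O)C=C[C@@]12O` differs from compound 3 in one place: 2-fluorophenyl in place of 4-hydroxyphenyl on a carbon with a double bond to nitrogen. Within the data shown here, the steps that bear on this change are those from a halogen-bearing phenyl, a 2.8-fold lower number from compound 1 to compound 3 (0.45 log units; beyond the scatter), and from a methoxy-bearing phenyl, a 1.8-fold lower number from compound 2 to compound 3 (0.24 log units; within the scatter), both of which set compound 3 at the low end of the series. A return to a halogen-bearing phenyl, this time with a single fluorine, is therefore expected to move the number back upward, by a step estimated as a 1.9-fold higher number from compound 3 to compound 4 (0.28 log units; within the scatter), though the small span among the three measured compounds keeps the expectation modest. Compound 4 is thus estimated to give about 38000 nM in this assay, within a range of 15000 nM to 90000 nM.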

Compound 4, half-maximal inhibitory concentration: 8200 nM
For compound 4 the middle estimate is 4.6-fold (0.67 log units) above the measured one; measured number below the stated range.
By their numbers in this assay, from the lowest: compound 4; then compounds 3, 2 and 1 (each within the scatter of the next, the first and the last beyond it).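

Compounds 1 to 3 spanned only a narrow range, but the aryl group on this carbon with a double bond to nitrogen now shows a wider reach in this assay: 2-fluorophenyl in place of 4-hydroxyphenyl gives the lowest number of the four compounds (a 2.4-fold lower number from compound 3 to compound 4 (0.39 log units; beyond the scatter)), and the step from the 4-methoxyphenyl of compound 2 is larger (a 4.3-fold lower number from compound 2 to compound 4 (0.63 log units; beyond the scatter)). A halogen on this phenyl does not by itself go with a higher number, since compound 1 and compound 4 both carry one yet stand at opposite ends of the series (a 6.8-fold lower number from compound 1 to compound 4 (0.83 log units; beyond the scatter)). The hydroxyl of compound 3 is also not needed for the lowest number seen here, as the 2-fluorophenyl of compound 4 has no hydrogen-bond donor.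

No measurement offered here explains why these steps run in this direction. The compounds shown leave open whether the fluorine itself accounts for the lower number, as they include no unsubstituted phenyl for comparison, and how an aminophenyl or a carboxyphenyl would behave at this position.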